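The compounds below may be only part of what the source reports. "The series", "measured", "known", "first", "only" and "open" are said of these compounds alone.

Compound 1, `C[C@@H](NC(=O)c1cc(Cl)ccc1O)C(=O)Nc1ccc(Cl)cc1`, in a functional assay on MCF7 cells (Homo sapiens) for cytotoxicity, with a stated time of 72 h; on this read-out higher numbers stand for weaker inhibition and lower numbers for stronger inhibition: > 20000 nM
Compound 2, `CC(C)[C@H](NC(=O)c1cc(Cl)ccc1O)C(=O)Nc1ccc(Cl)cc1`, in this assay: > 10000 nM
Compound 3, `CC(C)[C@H](NC(=O)c1ccc(Cl)cc1O)C(=O)Nc1ccc(Br)cc1`, in this assay: > 10000 nM

None of these three values is a measured number. Compound 3 stands at the limit of > 10000 nM in this assay, at which 2 of the 3 values shown sit. Compound 2 stands at that same limit. Compound 1 stands at the limit of > 20000 nM in this assay, at which 1 of the 3 values shown sits. A limit of this kind says only that the assay did not resolve a number; it does not rank the compounds against each other.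

Compound 4, `CC(C)[C@H](NC(=O)c1ccc(Cl)cc1O)C(=O)Nc1ccc(Cl)c(Cl)c1`, has not yet been tested. It differs from compound 3 in one place: 3,4-dichlorophenyl in place of 4-bromophenyl on an amide-type nitrogen. Within the data shown here, no single-point step between measured compounds is available, since compound 2 and compound 3 differ in two places, and all three values are limits. There is therefore no measured step to build on, and the three limits give no reason to expect that this change alone will bring compound 4 into the range the assay can resolve.

Compound 4 is expected to remain at or near the same limit, so the expected step that the limit leaves unreadable from compound 3 to compound 4 is no change beyond the scatter. The estimate for compound 4 is 15000 nM, with a range from 4000 nM to 60000 nM.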

Compound 4, half-maximal inhibitory concentration: > 10000 nM
Compound 4: a limit, no number (the forecaster's own chance of this, stated with the estimate: 75%); the middle value lies beyond the limit too.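

No step can be read from compound 3 to compound 4 in this assay, because both values are limits and not numbers: the limit of > 10000 nM in this assay, at which 3 of the 4 values shown sit.

The compounds shown leave open how 3,4-dichlorophenyl compares with 4-bromophenyl on an amide-type nitrogen, and whether any change to the shared core would give a resolved number in this assay.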